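Ring amide nitrogen substitution in the shared core

This account rests on a few compounds, and the source may have more. Where it says the series, first, only, none or still open, it means among the compounds named here.

Measured so far:
compound 1 `Cc1ccc(-c2cc(/N=C3/NC(=O)CS3)cs2)cc1`; in a functional assay on SW-620 cells (Homo sapiens) for cytotoxicity, read by MTT assay, with a stated time of 72 h (a lower number here means a stronger inhibitor, a higher number a weaker inhibitor), compound 1 gives > 50000 nM, a limit of the assay.
compound 2 `COc1ccc(-c2cc(/N=C3/NC(=O)CS3)cs2)cc1`; in this assay compound 2 gives > 50000 nM, again a limit.
compound 3 `O=C1CS/C(=N\c2csc(-c3ccc(Cl)cc3)c2)N1`; in this assay compound 3 gives > 50000 nM, also a limit.

Compound 1 thus stands at the limit of > 50000 nM in this assay, at which 3 of the 3 values shown sit. The steps a step that the two limits leave unreadable from compound 1 to compound 2, a step that the two limits leave unreadable from compound 1 to compound 3 and a step that the two limits leave unreadable from compound 2 to compound 3 are all unreadable between limits and concern only the substituent on the aromatic carbon.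

Compound 4 `COc1cccc(N2C(=O)CS/C2=N\c2csc(-c3ccc(C)cc3)c2)c1` differs from compound 1 by 3-methoxyphenyl in place of hydrogen on an amide-type nitrogen in a ring. Within the data shown here, no measured step touches this position, so no direction or size can be read from the series; the expectation is that compound 4 most likely remains near the limit, with only a weak chance of a readable number. Compound 4 is estimated at 40000 nM, range 5000 nM to 100000 nM, an expected step of an at least 1.2-fold lower number from compound 1 to compound 4 (0.09 log units; that floor lies within the scatter).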

Compound 4, half-maximal inhibitory concentration: > 50000 nM
Compound 4: only a limit was reported (the forecaster's own chance of this, stated with the estimate: 70%); at least 1.2-fold (0.09 log units) between middle value and limit.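

Compound 1 and compound 4 both stand at a limit, so no step can be read between them: the limit of > 50000 nM in this assay, at which 4 of the 4 values shown sit.

The compounds shown leave open whether 3-methoxyphenyl in place of hydrogen on the amide-type nitrogen changes the number at all.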